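The source may hold more compounds than are shown below. What is called first, only, known or untested is meant among the compounds shown, and "the series" means these compounds.

Compound 1 `NS(=O)(=O)CC(=O)NCCSc1nonc1/C(=N/O)Nc1cccc(C(F)F)c1` is one of two compounds with a value in an assay for inhibition of Indoleamine 2,3-dioxygenase 1 (Homo sapiens), read by fluorescence, with a stated time of 24 h; on this read-out lower numbers stand for stronger inhibition and higher numbers for weaker inhibition. In this assay, going by the values given here, compound 1 gives 17 nM, and compound 2 `CS(=O)(=O)NCCSc1nonc1/C(=N/O)Nc1ccc(F)c(Br)c1` gives 9.3 nM; these two numbers lie within the usual scatter of each other, so the data draw no line between them, and compound 2 differs from compound 1 in more than one place, so no single step links them. Compound 3 `N#Cc1cc(N/C(=N\O)c2nonc2SCCNC(=O)CS(N)(=O)=O)ccc1F` has not yet been measured. It differs from compound 1 only by 3-cyano-4-fluorophenyl in place of 3-(difluoromethyl)phenyl on an amine nitrogen, while the shared core and the sulfonamide-bearing side chain stay as in compound 1. Among the compounds with values here, no measured pair shows a change of this kind, so nothing in the data points to a shift beyond the scatter in either direction. The step from compound 1 to compound 3 in this assay is expected to be a 1.1-fold lower number from compound 1 to compound 3 (0.05 log units; within the scatter). Compound 3 is therefore estimated at 15 nM, with a range from 5 nM to 45 nM.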

Compound 3, half-maximal inhibitory concentration: 39 nM
For compound 3 the middle estimate is 2.6-fold (0.41 log units) below the measured one; low and high end bracket the measured number.
By their numbers in this assay, from the lowest: compounds 2 and 1 (each within the scatter of the next); then compound 3.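

With the shared core and the sulfonamide-bearing side chain held constant, the aryl group on the amine nitrogen can now be read on its own. In this assay, 3-cyano-4-fluorophenyl in place of 3-(difluoromethyl)phenyl gives a 2.3-fold higher number from compound 1 to compound 3 (0.36 log units; beyond the scatter), a modest step that shows this position responds to the choice of substituted phenyl, even though both groups count the same number of heavy atoms and each holds one six-membered aromatic ring. No measurement at hand accounts for this step.

The compounds shown leave open which part of 3-cyano-4-fluorophenyl carries the step, since none has the nitrile alone or the fluorine alone on this phenyl ring. They also leave open whether the same exchange would give a similar step on a side chain ending in an amine or a carboxylic acid.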